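Chloro in Place of Bromo on a Shared Core

The source may hold more compounds than are shown below. What is called first, only, known or untested is meant among the compounds shown, and "the series" means these compounds.

Measured compounds:
Compound 1 `Cc1cc(O)c(C(=O)/C=C/c2ccc3ccccc3c2)c(-c2ccccc2)c1C(=O)/C=C/c1ccc2ccccc2c1` gives 31500 nM in a functional assay on MCF7 cells (Homo sapiens) for cytotoxicity, read by MTT assay, with a stated time of 24 h; on this read-out lower numbers stand for stronger inhibition and higher numbers for weaker inhibition.
Compound 2 `Cc1cc(O)c(C(=O)/C=C/c2ccc(Cl)cc2)c(-c2ccc(Br)cc2)c1C(=O)/C=C/c1ccc(Cl)cc1` gives 20000 nM in this assay.
Compound 3 `Cc1cc(O)c(C(=O)/C=C/c2ccc(OCc3ccccc3)cc2)c(-c2ccc(OCc3ccccc3)cc2)c1C(=O)/C=C/c1ccc(OCc2ccccc2)cc1` gives 26000 nM in this assay.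

Compound 2 holds the lowest of the three numbers, yet its gaps to compound 3 and to compound 1 both lie within the usual scatter, so no order among the three can be read from them. Compound 4 `Cc1cc(O)c(C(=O)/C=C/c2ccc(Cl)cc2)c(-c2ccc(Cl)cc2)c1C(=O)/C=C/c1ccc(Cl)cc1` differs from compound 2 only by chloro in place of bromo on an aromatic carbon. Among the measured compounds shown here, no step between two measured compounds shows what such an exchange does on this core, so the expectation rests on the change alone, and a small one is expected, with no direction beyond the scatter. For compound 4 the estimate in this assay is 20000 nM, in a range from 10000 nM to 40000 nM, which means an expected step of no change at the digits printed from compound 2 to compound 4 (within the scatter).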

Compound 4, half-maximal inhibitory concentration: 28000 nM
The estimate for compound 4 lay 1.4-fold (0.15 log units) below the measured number; low and high end bracket the measured number.
By their numbers in this assay, from the lowest: compounds 2, 3, 4 and 1 (each within the scatter of the next).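

In this assay, among the compounds shown here, the change from 4-bromophenyl to 4-chlorophenyl gives a 1.4-fold higher number from compound 2 to compound 4 (0.15 log units; within the scatter), the only step on the shared core that differs in one place. At this aromatic carbon, para to a large group, bromo and chloro therefore cannot be told apart on this read-out. Nothing available bears on what lies behind this step. From the compounds shown here alone, whether an amine or a carboxylic acid on that same carbon would move the number beyond the scatter remains open. So does the result of a single exchange on the other aromatic rings.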